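The source may hold more compounds than are shown below. What is called first, only, known or untested is meant among the compounds shown, and "the series" means these compounds.

Compound 1 `O=C(N/N=C/c1cccc(Cl)c1Cl)Nc1ccc(Oc2ccnc3[nH]ccc23)cc1` gives "not active" (no number reported) with no number reported
Compound 2 `O=C(N/N=C/c1ccc(O)cc1)Nc1ccc(Oc2ccnc3[nH]ccc23)cc1` gives 1910 nM as its measured value

Among the measured compounds shown here, in a functional assay on A549 cells (Homo sapiens) for antiproliferative activity, read by MTT assay, with a stated time of 72 h (on this read-out lower numbers stand for stronger inhibition and higher numbers for weaker inhibition), compound 2 holds the only number so far. Compound 1 has no number, so compound 2 cannot be placed on a scale against another compound.

Still unmeasured is compound 3 `COc1ccc(/C=N/NC(=O)Nc2ccc(Oc3ccnc4[nH]ccc34)cc2)cc1`, which differs from compound 2 by methyl in place of hydrogen on an oxygen on an aromatic ring on an oxygen on an aromatic ring, with methyl in place of hydrogen. This is the change from hydroxy to methoxy, or from 4-hydroxyphenyl to 4-methoxyphenyl.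

For the measured compounds named here, the series offers no measured step between compounds that differ in one place, so the size of this change can only be judged loosely. The expectation in this assay is a step within the scatter, with a slight lean towards weaker inhibition. The estimated change is a 1.3-fold higher number from compound 2 to compound 3 (0.12 log units; within the scatter) and carries wide uncertainty. A result without a number, as seen for compound 1, remains possible. For compound 3 the estimated value is 2500 nM (expected range 700 nM to 9000 nM).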

Compound 3, half-maximal inhibitory concentration: 4300 nM
The estimate for compound 3 lay 1.7-fold (0.24 log units) below the measured number; low and high end bracket the measured number.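

In this assay, among the compounds shown here, the step of a 2.3-fold higher number from compound 2 to compound 3 (0.35 log units; beyond the scatter) is the first measured comparison between two compounds that differ in one place. It shows that the hydrogen on the oxygen on the aromatic ring is not a neutral site: going from 4-hydroxyphenyl to 4-methoxyphenyl, with methyl in place of hydrogen, moves the number beyond the usual scatter towards weaker inhibition, although the step is modest and rests on this single pair. No measurement on the two compounds accounts for the shift, so the result stands as an observation without a known cause.

Open, from the compounds shown here alone, is how this site responds to groups other than hydroxy and methoxy: an amine or a carboxylic acid in place of the hydroxy, or a longer chain such as ethoxy on the same oxygen, would show whether the trend to weaker inhibition continues or reverses. For the compounds shown here, also open is whether the same step appears on another substitution pattern of this ring, since the single pair gives no second reading of the change.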